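The compounds below may be only part of what the source reports. "The series", "measured", "known", "first", "only" and "open" are said of these compounds alone.

Compounds measured in a functional assay on HBL-100 cells (Homo sapiens) for inhibition, read by sulforhodamine B assay, with a stated time of 48 h; on this read-out lower numbers stand for stronger inhibition of growth and higher numbers for weaker inhibition of growth:
compound 1 `O=C(/C(=C/c1ccccc1)CCl)c1ccccc1` gives 12000 nM; compound 2 `CC(=O)OC/C(=C\c1ccccc1)C(=O)c1ccccc1` gives 17000 nM.

For the measured compounds named here, compound 2 and compound 1 are the only two numbers so far, and they lie within the scatter of each other: the one known step, a 1.4-fold higher number from compound 1 to compound 2 (0.15 log units; within the scatter), exchanges chloro for acetoxy on the chain. Compound 3 `CC(=O)OC/C(=C\c1ccc(F)cc1)C(=O)c1ccccc1` differs from compound 2 by fluoro in place of hydrogen on an aromatic carbon, para to a large group. Going by the values given here, no measured step touches that aromatic ring. For compound 3 no step beyond the scatter is therefore expected, no change at the digits printed from compound 2 to compound 3 (within the scatter). Compound 3 is estimated at 17000 nM, between 8000 nM and 36000 nM.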

Compound 3, concentration for 50% growth inhibition: 17000 nM
The estimate for compound 3 equals the measured number at the digits printed; the range from low to high includes it.
By their numbers in this assay, from the lowest: compounds 1, 2 and 3 (each within the scatter of the next).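

In this assay, phenyl to 4-fluorophenyl leaves growth inhibition in place, with no change at the digits printed from compound 2 to compound 3 (within the scatter). For the compounds shown here, this is the first look at the aromatic ring on the alkene side: fluoro on an aromatic carbon, para to a large group, is tolerated here, whereas the earlier step touched only the chain. No measurement shown gives a reason for this result. The compounds shown leave open whether an amine, a methoxy group or a carboxylic acid at that ring carbon would shift the number, and whether the other phenyl ring tolerates any change.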